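A few compounds are considered here, and "the series" means these few. Any claim that something is new, unique, unknown or untested is made for them only; others in the source may bear on it.

Working notes on the series. Within the data shown here, compound 1 `C[C@H](Nc1nc(N)nc(N)c1C#N)c1cc2ccc(F)cn2c(=O)c1-c1ccccc1` is the lower of the two numbers so far in a physicochemical assay for lipophilicity, at pH 7.4; a lower number here means a more polar compound, a higher number a more lipophilic compound: compound 1 gives 1.26, while compound 2 `C[C@H](Nc1nc(N)nc(N)c1C#N)c1cc(=O)n2cc(F)ccc2c1-c1cc(F)cc(F)c1` in this assay gives 1.88, a gap beyond the scatter. Compound 3 `C[C@H](Nc1nc(N)nc(N)c1C#N)c1c(-c2ccccc2)c(=O)n2cc(F)ccc2c1-c1ccccc1` carries phenyl in place of hydrogen on an aromatic carbon, phenyl in place of hydrogen on an aromatic carbon. Among the measured compounds shown here, no two measured compounds differ by such a change, so the step has no measured counterpart; an upward step from compound 1 to compound 3 of a number 1.54 log units higher from compound 1 to compound 3 (beyond the scatter) is expected, well beyond the scatter. Compound 3 is estimated at 2.8 in this assay, within 2.2 to 3.5.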

Compound 3, distribution coefficient: 2.49
The estimate for compound 3 lay 0.31 log units above the measured number; low and high end bracket the measured number.
By their numbers in this assay, from the lowest: compound 1; then compound 2; then compound 3.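

Among these compounds, the first single-place step falls at this aromatic carbon, ortho to a fused ring and two atoms from the ring nitrogen. In this assay phenyl in place of hydrogen gives a number 1.23 log units higher from compound 1 to compound 3 (beyond the scatter) and so shows that a change at this position alone can move the number by a large step. Nothing at hand explains the size of this step.

On these data alone, whether methyl, an amine or a carboxylic acid at this position would move the number in the same direction remains open. So does whether phenyl gives a similar step on the core of compound 2.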